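This account rests on a few compounds, and the source may have more. Where it says the series, first, only, none or still open, it means among the compounds named here.

Working notes on the triazole sulfonamide series, read in an ADME assay on GES1 cells (Homo sapiens) for cytotoxicity, read by MTT assay, with a stated time of 24 h; on this read-out lower numbers stand for higher toxicity in this test and higher numbers for lower toxicity in this test. Three compounds have entries there. Compound 1 `O=c1[nH]cc(S(=O)(=O)Nc2ccccc2-c2cn(-c3cccc(F)c3)nn2)c(=O)[nH]1` is recorded as "not toxic" (no number reported), and compound 2 `O=c1[nH]cc(S(=O)(=O)Nc2cccc(-c3cn(-c4cccc(F)c4)nn3)c2)c(=O)[nH]1` likewise as "not toxic" (no number reported); neither carries a number, so neither can anchor a comparison. Among the compounds with values here, compound 3 `Cc1cccc(-n2cc(-c3ccc(NS(=O)(=O)c4c[nH]c(=O)[nH]c4=O)cc3)nn2)c1` is the only member with a measured figure: in this assay compound 3 gives 28300 nM. On the numbers shown, compound 3 therefore stands alone, with the two further entries offering only a qualitative reading and no ordering relative to it.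

The next compound, compound 4 `O=c1[nH]cc(S(=O)(=O)Nc2ccc(-c3cn(-c4ccc(F)cc4)nn3)cc2)c(=O)[nH]1`, differs from compound 3 in one place: 4-fluorophenyl in place of 3-methylphenyl on an aromatic nitrogen. Within the data shown here, no step between two measured compounds is available in this assay, so no size for this kind of exchange has been observed. The shared core and the sulfonamide linkage are untouched. Given that the only measured value, compound 3 at 28300 nM, sits far from any potent cytotoxic range, the exchange is expected to shift the read-out by no more than the scatter, in no fixed direction. For compound 4 the estimated step of a 1.2-fold higher number from compound 3 to compound 4 (0.09 log units; within the scatter) is accordingly small. Compound 4 is thus expected at 35000 nM, within 12000 nM to 100000 nM, with a fair chance that only a qualitative "not toxic" entry results.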

Compound 4, half-maximal cytotoxic concentration: > 100000 nM
Compound 4 was reported as a limit; the forecaster's own chance of this, stated with the estimate: 35%; middle value at least 2.8-fold (0.45 log units) from the limit.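

In this assay, within the data shown here, 4-fluorophenyl in place of 3-methylphenyl on an aromatic nitrogen gives an at least 3.5-fold higher number from compound 3 to compound 4 (0.54 log units; beyond the scatter), the first step that can be read and the first sign that the read-out responds to a change at this position. For compound 4 the entry > 100000 nM is a limit of the assay and not a number. The size of the step is therefore fixed from one side only, and it is read against this limit: the limit of > 100000 nM in this assay, at which 1 of the 4 values shown sits.

The single exchange removes the methyl and brings in the fluorine at a different place on the phenyl ring, and the compounds shown do not separate the group from its place. Going by these compounds, how an unsubstituted phenyl, a methoxyphenyl or a phenyl carrying an amine would read on this nitrogen remains open, as does whether any other member of the series would give a number rather than a limit or a qualitative entry.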